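Methyl branching on the side chain of benzyl-protected sugar analogues

The source may hold more compounds than are shown below. What is called first, only, known or untested is meant among the compounds shown, and "the series" means these compounds.

Measured so far:
compound 1 `CCC[C@@H]1O[C@H](COCc2ccccc2)[C@@H](OCc2ccccc2)[C@H](OCc2ccccc2)[C@H]1O` — 18900 nM
compound 2 `CC(C)C[C@@H]1O[C@H](COCc2ccccc2)[C@@H](OCc2ccccc2)[C@H](OCc2ccccc2)[C@H]1O` — > 50000 nM
compound 3 `CCC[C@@H]1O[C@H](COCc2ccccc2)[C@@H](OCc2ccccc2)[C@H](OCc2ccccc2)C1=O` — > 50000 nM

Within the data shown here, compound 1 is the only member with a numbered result: in a functional assay on HeLa cells (Homo sapiens) for antiproliferative activity, read by sulforhodamine B assay (on this read-out higher numbers stand for weaker inhibition of growth and lower numbers for stronger inhibition of growth), compound 1 gives 18900 nM. Compound 2 reaches only the assay limit of > 50000 nM in this assay. Compound 3 likewise sits at the limit of > 50000 nM in this assay. The step of an at least 2.6-fold higher number from compound 1 to compound 2 (0.42 log units; beyond the scatter) is therefore known only as a lower bound, because the limit of > 50000 nM in this assay, at which 2 of the 3 values shown sit, caps what can be read; the change itself is methyl in place of hydrogen on a saturated chain carbon bound to two saturated chain carbons.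

Compound 4 `CC(C)C[C@@H]1O[C@H](COCc2ccccc2)[C@@H](OCc2ccccc2)[C@H](OCc2ccccc2)C1=O` is not yet measured. It differs from compound 3 by methyl in place of hydrogen on a saturated chain carbon bound to two saturated chain carbons, the same change as from compound 1 to compound 2. How the core of compound 3 differs from that of compound 1 is not broken down here.

For this assay the expected step is a step that the limit leaves unreadable from compound 3 to compound 4, resting on the direction of an at least 2.6-fold higher number from compound 1 to compound 2 (0.42 log units; beyond the scatter) and on compound 3 already standing at > 50000 nM. Compound 4 is estimated at 120000 nM, most likely reported only as a limit.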

Compound 4, concentration for 50% growth inhibition: > 50000 nM
Compound 4: a limit, no number; the forecaster's own chance of this, stated with the estimate: 85%; the middle value does not contradict the limit.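

No step from compound 3 to compound 4 can be read in this assay, because both compounds give a limit and no number: the limit of > 50000 nM in this assay, at which 3 of the 4 values shown sit.

From the compounds shown here alone, whether methyl in place of hydrogen on a saturated chain carbon bound to two saturated chain carbons changes growth inhibition on the core of compound 3 stays open.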